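Bromine Removal on Two Cores: Toxicity in Macrophages

The source may report more compounds than this note shows. Statements on the series, on what has been measured and on what is new or still open speak of the compounds shown alone.

Compound 1 `Nc1ncnn2c([C@@H]3O[C@H](CO)[C@@H](O)[C@H]3O)cc(Br)c12`: in an ADME assay on cells (Macrophage, Mus musculus) for cytotoxicity (on this read-out higher numbers stand for lower toxicity in this test and lower numbers for higher toxicity in this test), compound 1 gives 2000 nM.
Compound 2 `Nc1ncnn2c([C@@H]3O[C@H](CO)[C@@H](O)[C@H]3O)ccc12`: in this assay compound 2 gives < 250 nM, which is a limit of the assay.
Compound 3 `O=c1[nH]cnn2c([C@@H]3O[C@H](CO)[C@@H](O)[C@H]3O)cc(Br)c12`: in this assay compound 3 gives > 64000 nM, which is also a limit of the assay.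

Compound 1 and compound 2 share one core and differ only by hydrogen in place of bromo on an aromatic carbon. That change produced an at least 8.0-fold lower number from compound 1 to compound 2 (0.90 log units; beyond the scatter). Compound 3 carries a different core; the difference between the two cores is not broken down here. Compound 4 `O=c1[nH]cnn2c([C@@H]3O[C@H](CO)[C@@H](O)[C@H]3O)ccc12`, still to be measured, differs from compound 3 by hydrogen in place of bromo on an aromatic carbon, the same change made on the other core. For compound 4 a step of an at least 4.0-fold lower number from compound 3 to compound 4 (0.60 log units; beyond the scatter) is expected, since compound 3 sits at a limit and mainly the direction of an at least 8.0-fold lower number from compound 1 to compound 2 (0.90 log units; beyond the scatter) can be carried over. Compound 4 is therefore estimated at 16000 nM, with a range from 2000 nM to 100000 nM.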

Compound 4, half-maximal cytotoxic concentration: > 64000 nM
Compound 4: no number, only a limit; the forecaster's own chance of this, stated with the estimate: 40%; at least 4.0-fold (0.60 log units) between middle value and limit.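

Compound 3 and compound 4 sit at the same limit in this assay, so no step can be read between them: the limit of > 64000 nM in this assay, at which 2 of the 4 values shown sit.

The compounds shown leave open whether hydrogen in place of bromo changes the read-out at all on the core of compound 3.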